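Compound 2 to compound 3: a change at the carbonyl

The compounds below may be only part of what the source reports. "The series", "measured", "known", "first", "only" and "open" are said of these compounds alone.

Of the compounds shown here, two sharing one core have been measured so far in a functional assay on P388 cells (Mus musculus); a higher number here means a weaker inhibitor, a lower number a stronger inhibitor. Compound 1 `CN(C)CC1CCC/C(=C\c2ccc(OC(=O)/C=C/c3ccc(F)cc3)cc2)C1=O` gives 4550 nM, and compound 2 `CN(C)CC1CCC/C(=C\c2ccc(OC(=O)/C=C/c3ccc(Br)cc3)cc2)C1=O` gives 4030 nM. These two values lie within the usual scatter of each other, so compound 2 stands level with compound 1 on the numbers available.

The next compound, compound 3 `CN(C)CC1CCC/C(=C\c2ccc(OC(=O)c3ccccc3)cc2)C1=O`, carries phenyl in place of 2-(4-bromophenyl)ethenyl on a carbonyl carbon. Among the measured compounds shown here, only one measured step bears on this change: a 1.1-fold lower number from compound 1 to compound 2 (0.05 log units; within the scatter), with bromo in place of fluoro on an aromatic carbon. That step altered a single atom within the group that now leaves, and it stayed within the scatter. For the measured compounds named here, no measured compound shows what happens when the whole group is exchanged, so the data give no direction, and no step beyond the scatter is expected in this assay. The estimated step is a 1.1-fold higher number from compound 2 to compound 3 (0.05 log units; within the scatter). For compound 3 the expected value is 4500 nM, with an estimated range of 1800 nM to 11000 nM.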

Compound 3, half-maximal inhibitory concentration: 180 nM
The estimate for compound 3 lay 25-fold (1.40 log units) above the measured number; measured number outside the range, below it.
By their numbers in this assay, from the lowest: compound 3; then compounds 2 and 1 (each within the scatter of the next).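

The earlier pair differed only by bromo in place of fluoro on an aromatic carbon, a change that stayed within the scatter, so it gave no sign that the group on this carbonyl carbon mattered in this assay. Exchanging the whole group tells a different story, with a 22-fold lower number from compound 2 to compound 3 (1.35 log units; beyond the scatter) and a 25-fold lower number from compound 1 to compound 3 (1.40 log units; beyond the scatter) when phenyl takes the place of the 2-(4-halophenyl)ethenyl group. The position is therefore far from indifferent to what sits on it, at least across these three compounds, although nothing measured here explains the size of these steps.

The exchange changes more than one thing at once, since phenyl has neither the halogen nor the double bond outside aromatic rings, and the compounds shown do not separate these two differences. A 4-bromophenyl group on the same carbonyl carbon would keep the halogen without the double bond, while a 2-phenylethyl chain would keep the length of the group without that double bond, and either could show which part of the exchange goes with the lower number.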